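The compounds below may be only part of what the source reports. "The series", "measured", "known", "first", "only" and "open" are said of these compounds alone.

Working notes on the cytotoxicity series. Compound 1 `CC(C)(C)OC(=O)NCCCCNCCCN(Cc1cccc(-c2ccccc2)c1)Cc1cccc(-c2ccccc2)c1` carries a tert-butoxycarbonyl group on an amine nitrogen; in an ADME assay on RAW264.7 cells (Mus musculus) for cytotoxicity, read by resazurin assay, with a stated time of 48 h (a lower number here means that less compound is tolerated, a higher number that more compound is tolerated), compound 1 gives > 100000 nM, which is a limit of the assay and not a number. Compound 2 `NCCCCNCCCN(Cc1cccc(-c2ccccc2)c1)Cc1cccc(-c2ccccc2)c1` lacks that group; in this assay compound 2 gives 30300 nM. The change between them is hydrogen in place of tert-butoxycarbonyl on an amine nitrogen and it produces an at least 3.3-fold lower number from compound 1 to compound 2 (0.51 log units; beyond the scatter); the step is stated only as a bound because compound 1 sits at the limit of > 100000 nM in this assay, at which 1 of the 3 values shown sits. Compound 3 `CC(C)(C)OC(=O)NC1CCC(NCCCN(Cc2ccc(F)cc2)Cc2ccc(F)cc2)CC1` belongs to a second core; in this assay compound 3 gives 4200 nM, the lowest of the two numbers recorded so far. The difference between the two cores is not broken down here.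

Compound 4 `NC1CCC(NCCCN(Cc2ccc(F)cc2)Cc2ccc(F)cc2)CC1` has not yet been tested. It differs from compound 3 by hydrogen in place of tert-butoxycarbonyl on an amine nitrogen. This is the same kind of change as that from compound 1 to compound 2, though not the same one: in compound 1 the other neighbour of the amine nitrogen is a saturated chain carbon, in compound 3 it is a saturated ring carbon. Among the measured compounds shown here, for compound 4 in this assay a step of a 2.1-fold lower number from compound 3 to compound 4 (0.32 log units; beyond the scatter) is expected, resting on the one earlier instance an at least 3.3-fold lower number from compound 1 to compound 2 (0.51 log units; beyond the scatter), which is only a bound and comes from the other core. Compound 4 is accordingly estimated at 2000 nM, with a range from 800 nM to 6000 nM.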

Compound 4, half-maximal cytotoxic concentration: 4400 nM
Compound 4: the middle estimate sits 2.2-fold (0.34 log units) below what was measured; the range from low to high includes it.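

Taking the tert-butoxycarbonyl group off the amine nitrogen on the core of compound 3 gives no change beyond the scatter in this assay, a 1.0-fold higher number from compound 3 to compound 4 (0.02 log units; within the scatter), so the size of the step seen on the core of compound 1 did not carry over to this core: the same change on two cores in this assay, an at least 3.3-fold lower number (0.51 log units; beyond the scatter) from compound 1 to compound 2 and a 1.0-fold higher number (0.02 log units; within the scatter) from compound 3 to compound 4, at least 3.4-fold (0.53 log units) apart, beyond the scatter of two such steps. The earlier step and the gap between the two steps are bounds and not exact sizes: the limit of > 100000 nM in this assay, at which 1 of the 4 values shown sits. Two pairs do not show which difference between the cores goes with this gap, since the other neighbour of the amine nitrogen, a saturated chain carbon in compound 1 and a saturated ring carbon in compound 3, is only one of several differences between them.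

On these data alone, it remains open whether the outcome follows that neighbouring carbon or the rest of the core, a question that would need a saturated ring carbon at that place on the core of compound 1 and a saturated chain carbon there on the core of compound 3. As far as these compounds go, it is also open whether an acetyl group in place of tert-butoxycarbonyl on the same nitrogen would follow either of the two pairs in this assay.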